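Fluoro-to-hydrogen exchange on an aryl ring and cytotoxicity

The source may hold more compounds than are shown below. What is called first, only, known or untested is meant among the compounds shown, and "the series" means these compounds.

Measured compounds:
compound 1, `O=C1CCCC2=C1C(c1ccc(F)cc1)N=C(c1cccnc1)N2`, 281000 nM
compound 2, `O=C1CCCC2=C1C(c1ccccc1)N=C(c1cccnc1)N2`, 369000 nM
compound 3, `CC1(C)CC(=O)C2=C(C1)NC(c1cnccn1)=NC2c1ccc(F)cc1Cl`, 773000 nM

In an ADME assay on HepG2 2.2.15 cells (Homo sapiens) for cytotoxicity (on this read-out higher numbers stand for weaker inhibition and lower numbers for stronger inhibition), compound 1 gives 281000 nM and compound 2 gives 369000 nM. The two differ by hydrogen in place of fluoro on an aromatic carbon, and the step is a 1.3-fold higher number from compound 1 to compound 2 (0.12 log units; within the scatter). Compound 3 sits on a different core; the difference between the two cores is not broken down here. Compound 3 gives 773000 nM, the highest of the three numbers, beyond the scatter from both compound 1 and compound 2.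

Compound 4, `CC1(C)CC(=O)C2=C(C1)NC(c1cnccn1)=NC2c1ccccc1Cl`, has not been measured. It differs from compound 3 by hydrogen in place of fluoro on an aromatic carbon. This is the same kind of change as that from compound 1 to compound 2, though here the place is also meta to a chloro group, whereas in the earlier pair it is only para to a large group. Because the earlier step was a 1.3-fold higher number from compound 1 to compound 2 (0.12 log units; within the scatter), the step from compound 3 to compound 4 is expected to be small as well, about a 1.2-fold higher number from compound 3 to compound 4 (0.09 log units; within the scatter). Compound 4 is therefore estimated at 950000 nM, with a plausible range from 450000 nM to 2000000 nM.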

Compound 4, half-maximal inhibitory concentration: 623000 nM
Estimate against measurement, compound 4: 1.5-fold (0.18 log units) above, and the stated range covers the measured number.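

In this assay, the same exchange on the other core gives a 1.2-fold lower number from compound 3 to compound 4 (0.09 log units; within the scatter), so going from 2-chloro-4-fluorophenyl to 2-chlorophenyl leaves the read-out within the scatter. Set beside the earlier pair, the two steps cannot be told apart, and the exchange reads the same on both cores: the same change on two cores in this assay, a 1.3-fold higher number (0.12 log units; within the scatter) from compound 1 to compound 2 and a 1.2-fold lower number (0.09 log units; within the scatter) from compound 3 to compound 4, 1.6-fold (0.21 log units) apart, within the scatter of two such steps. This shows that, on these two cores, fluoro and hydrogen at this place on the aromatic ring give numbers that repeated measurement would not separate, but it does not show that the steps truly run in opposite directions, and two pairs set no rule for other cores in the series.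

The compounds shown leave open what a different group at this place on the ring would do, such as a methoxy group, an amine or a carboxylic acid. Among the compounds shown here, they also leave open how the chloro group itself bears on the read-out, since no pair here differs in that group alone.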